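Swapping Iodo for Isopropyl on a Shared Core

This account rests on a few compounds, and the source may have more. Where it says the series, first, only, none or still open, it means among the compounds named here.

Measured so far in an ADME assay on TZM cells (Homo sapiens) for cytotoxicity; a higher number here means that more compound is tolerated, a lower number that less compound is tolerated:
- compound 1 `CC(C)c1c(O[C@H]2CCCC[C@@H]2C)cc(CCc2ccccc2)[nH]c1=O` reads > 300000 nM, a limit of the assay rather than a number.
- compound 2 `CC(C)c1c(Cc2ccccc2)n(COCc2ccccc2)c(=O)[nH]c1=O` reads 65800 nM.
- compound 3 `CC1CCCCC1Oc1cc(CCc2ccccc2)[nH]c(=O)c1I` reads > 300000 nM, again a limit of the assay.

Compound 3 thus stands at the ceiling of what this assay reports: the limit of > 300000 nM in this assay, at which 2 of the 3 values shown sit. Compound 4 `CC(C)c1c(OC2CCCCC2C)cc(CCc2ccccc2)[nH]c1=O` is drawn from compound 3 by a single change, (isopropyl in place of iodo on an aromatic carbon). Going by the values given here, no step between measured compounds is available to calibrate this change. Compound 1, which already carries the isopropyl, also sits at that limit. The step from compound 3 to compound 4 is expected to be none beyond the usual scatter, a number no higher from compound 3 to compound 4 (the limit leaves the size open). That expectation rests on (the limit of > 300000 nM in this assay, at which 2 of the 3 values shown sit). Compound 4 is estimated at 300000 nM, within a range from 150000 nM to 600000 nM, and most likely reported once more as a limit.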

Compound 4, half-maximal cytotoxic concentration: 114000 nM
Beside the measured number, compound 4's estimate is 2.6-fold (0.42 log units) above it; measured number below the stated range.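

In this assay, swapping the iodo group for an isopropyl group brings the reading down from the limit to a measurable number, with an at least 2.6-fold lower number from compound 3 to compound 4 (0.42 log units; beyond the scatter). Isopropyl alone does not settle the reading, since the same atoms and bonds also give an at least 2.6-fold lower number from compound 1 to compound 4 (0.42 log units; beyond the scatter), and the difference there lies only in the drawn stereochemistry: the fact that one of compounds 1 and 4 is drawn with a defined configuration and the other without, at the place where they differ. From the compounds shown here alone, both steps start from a limit, so their full size stays unknown: the limit of > 300000 nM in this assay, at which 2 of the 4 values shown sit.

Going by these compounds alone, it remains open whether a configuration other than the one drawn in compound 1 lowers the number. Going by these compounds, how an amine or a longer chain would read at this position also remains open.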